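The source may hold more compounds than are shown below. What is called first, only, known or untested is meant among the compounds shown, and "the series" means these compounds.

Of the compounds shown here, three with a shared core have been measured in an assay on HEK293 cells for inhibition of Fatty-acid amide hydrolase 1 (Homo sapiens), read by fluorescence; on this read-out higher numbers stand for weaker inhibition and lower numbers for stronger inhibition. Compound 1 `Cn1ccc2cc(-c3ccc4oc(Cc5ccccc5)nc4c3)ccc21` gives 488 nM, compound 2 `CN(c1ccccc1)c1nc2cc(-c3ccc4c(ccn4C)c3)ccc2o1` gives 68 nM, and compound 3 `COc1ccc(Nc2nc3cc(-c4ccc5c(ccn5C)c4)ccc3o2)cc1` gives 280 nM. Compound 3 therefore carries the second highest of the three numbers: the step of a 1.7-fold lower number from compound 1 to compound 3 (0.24 log units; within the scatter) lies within the scatter, while a 4.1-fold higher number from compound 2 to compound 3 (0.61 log units; beyond the scatter) is a modest step beyond it, and a 7.2-fold lower number from compound 1 to compound 2 (0.86 log units; beyond the scatter) separates the two ends of the set.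

The next compound, compound 4 `CNc1nc2cc(-c3ccc4c(ccn4C)c3)ccc2o1`, differs from compound 3 in one place: methyl in place of 4-methoxyphenyl on a nitrogen on an aromatic ring. Among the compounds with values here, none of the measured steps tests this change directly. The step from compound 2 to compound 3 exchanged one group on the nitrogen for another while keeping an aromatic ring there, and the steps from compound 1 replaced the whole group. Compound 4 removes the ring altogether, so the three steps only bound the expectation loosely. A weakening is expected, with a 2.5-fold higher number from compound 3 to compound 4 (0.40 log units; beyond the scatter) as the estimated step, and with wide uncertainty. Compound 4 is therefore expected to give about 700 nM, somewhere between 200 nM and 2500 nM.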

Compound 4, half-maximal inhibitory concentration: > 1000 nM
Compound 4: a limit, no number; the forecaster's own chance of this, stated with the estimate: 10%; at least 1.4-fold (0.15 log units) between middle value and limit.
By their numbers in this assay, from the lowest: compound 2; then compounds 3 and 1 (each within the scatter of the next). At a limit, above all of these: compound 4.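

Compound 4 stands at a limit of the assay, not at a number: the limit of > 1000 nM in this assay, at which 1 of the 4 values shown sits. It is the only compound shown with no aromatic ring in the group at this position, and an at least 3.5-fold higher number from compound 3 to compound 4 (0.55 log units; beyond the scatter) and an at least 14-fold higher number from compound 2 to compound 4 (1.16 log units; beyond the scatter) show that a small methyl on the nitrogen on an aromatic ring does not keep the inhibition that either ring-bearing amine gives. Even an at least 2.0-fold higher number from compound 1 to compound 4 (0.31 log units; beyond the scatter) points the same way, so methylamino also falls short of benzyl, a group with a ring but no such nitrogen.

The limit leaves the full size of these steps open. Also open, as far as these compounds go, is whether an aromatic ring is needed on that nitrogen or whether a cyclohexyl group or a longer chain such as butyl would serve as well.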